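A few compounds are considered here, and "the series" means these few. Any claim that something is new, unique, unknown or untested is made for them only; others in the source may bear on it.

In a functional assay on the whole organism (strain NMRI) with Mus musculus as the target, with a stated time of 60 min, at a dose of 10 mg/kg by the intraperitoneal route (on this read-out higher numbers stand for a stronger effect at the one dose given and lower numbers for a weaker effect), two compounds have been measured. Compound 1 `CCSc1nnc(Cc2ccccc2Oc2ccccc2)[nH]1` gives 142% in this assay. Compound 2 `CSc1nnc(Cc2ccc(Cl)cc2Oc2ccccc2Cl)[nH]1` gives 132% in this assay. Compound 2 holds the second of the two numbers, yet the gap to compound 1 lies within the usual scatter of repeated measurements, so the two cannot be told apart on these readings; the two structures also differ in more than one place, so their values show only that both are active at the dose used.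

Compound 3 `Clc1ccc(Cc2nnc(SCc3ccccc3)[nH]2)c(Oc2ccccc2Cl)c1` has not yet been measured in this assay. It differs from compound 2 in one place: phenyl in place of hydrogen on a saturated chain carbon bound to a sulfur. Among the compounds with values here, no measured pair shows what this change does here. With nothing to guide direction, no step beyond the scatter is expected from compound 2 to compound 3 in this assay, and the expected step of a number 7 percentage points lower from compound 2 to compound 3 (within the scatter) is therefore small. Compound 3 is estimated at 125% in this assay, within a range from 90% to 160%.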

Compound 3, a percentage reported as activity, at one dose (the size of the read-out at that dose, not a potency): 122%
The estimate for compound 3 lay 3 percentage points above the measured number, within the range that was stated.
By their numbers in this assay, from the lowest: compounds 3, 2 and 1 (each within the scatter of the next, the first and the last beyond it).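

Within the data shown here, compound 2 and compound 3 differ in one place only, so they give the first clean comparison of this series: going from methylsulfanyl to benzylsulfanyl in this assay gives a step of (a number 10 percentage points lower from compound 2 to compound 3 (within the scatter)). A phenyl group, a six-membered aromatic ring of carbon only, can therefore stand in place of hydrogen on the saturated chain carbon bound to the sulfur without a change that can be told from the scatter at the one dose used, and the activity of the series does not depend on keeping the small methyl group there. No measurement is available that would explain this outcome.

As far as these compounds go, what remains open is whether this position accepts groups of a different kind, such as an amine or a carboxylic acid at the end of the chain on the sulfur, or a longer chain carrying the phenyl ring. A single pair at a single dose also leaves open whether benzylsulfanyl would behave the same way on the core of compound 1, and whether a difference in potency lies hidden behind these similar readings.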